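The source may hold more compounds than are shown below. What is called first, only, known or untested is meant among the compounds shown, and "the series" means these compounds.

Measured in a functional assay on A-375 cells (Homo sapiens) for antiproliferative activity; a lower number here means a stronger inhibitor, a higher number a weaker inhibitor:

- Compound 1 `O=C(Nc1ccc(-c2cccnc2)cc1)C1CCCN(Cc2ccc(F)c(F)c2)C1`: 610 nM
- Compound 2 `O=C(Nc1ccc(-c2nccs2)cc1)C1CCCN(Cc2ccc(F)c(F)c2)C1`: 240 nM
- Compound 3 `O=C(Nc1ccc(-c2ccco2)cc1)C1CCCN(Cc2ccc(F)c(F)c2)C1`: 1040 nM

Compound 3 belongs with compound 1 at the upper end of this small set, since the step between them is a 1.7-fold higher number from compound 1 to compound 3 (0.23 log units; within the scatter). Compound 2 stands apart from both, with a 2.5-fold lower number from compound 1 to compound 2 (0.41 log units; beyond the scatter) and a 4.3-fold higher number from compound 2 to compound 3 (0.64 log units; beyond the scatter).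

Compound 4 `O=C(Nc1ccc(-c2cc[nH]c2)cc1)C1CCCN(Cc2ccc(F)c(F)c2)C1` keeps the shared core and changes only the ring that compound 3 carries: 1H-pyrrol-3-yl in place of furan-2-yl on an aromatic carbon, (1H-pyrrol-3-yl in place of furan-2-yl on an aromatic carbon). Going by the values given here, no measured compound has this group, so the three measured swaps at this same place are the only guide. They range from a step within the scatter to a modest one. With compound 3 at the upper end of that range, a modest move in this assay toward a lower number is expected, though a result within the scatter would be no surprise. The expected change is a 1.9-fold lower number from compound 3 to compound 4 (0.28 log units; within the scatter). For compound 4 the estimated value is 550 nM, with an expected range from 220 nM to 1400 nM.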

Compound 4, half-maximal inhibitory concentration: 1420 nM
For compound 4 the middle estimate is 2.6-fold (0.41 log units) below the measured one; the whole stated range lies below it.
By their numbers in this assay, from the lowest: compound 2; then compounds 1, 3 and 4 (each within the scatter of the next, the first and the last beyond it).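

In this assay, the exchange of furan-2-yl for 1H-pyrrol-3-yl removes a hydrogen-bond acceptor and adds a hydrogen-bond donor, yet the result stays within the scatter (a 1.4-fold higher number from compound 3 to compound 4 (0.14 log units; within the scatter)). The 1,3-thiazol-2-yl of compound 2 now stands apart from a third ring as well (a 5.9-fold higher number from compound 2 to compound 4 (0.77 log units; beyond the scatter)), making compound 2 the most potent of the four compounds. A gap beyond the scatter also appears within the weaker group (a 2.3-fold higher number from compound 1 to compound 4 (0.37 log units; beyond the scatter)), although compound 3 does not separate from either of these two compounds.

Nothing available explains why these rings differ at this position. Going by these compounds, it remains open whether an amine or a carboxylic acid on this aromatic carbon would match compound 2 in this assay.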